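Adding a Methyl to the Ester Chain: Toxicity Expected Unchanged

This account rests on a few compounds, and the source may have more. Where it says the series, first, only, none or still open, it means among the compounds named here.

Three compounds with a shared core were tested in a toxicity assay on L02 cells (Homo sapiens) for cytotoxicity, read by MTT assay, with a stated time of 24 h; on this read-out higher numbers stand for lower toxicity in this test and lower numbers for higher toxicity in this test. Compound 1 `CCCCS(=O)(=O)Oc1ccc(/C=C/C(=O)Nc2ccccc2)cc1OC` gives 3320 nM in this assay. Compound 2 `CCCCS(=O)(=O)Oc1ccc(/C=C/C(=O)OCC)cc1OC` gives 14400 nM. Compound 3 `CCCOC(=O)/C=C/c1ccc(OS(=O)(=O)c2ccc(Cl)cc2)c(OC)c1` gives 150000 nM, the highest of the three numbers, which makes it the least toxic of the measured set; its gaps to compound 2 and to compound 1 both lie beyond the usual scatter of this assay. Going by the values given here, the only measured single-site step, a 4.3-fold higher number from compound 1 to compound 2 (0.64 log units; beyond the scatter), concerns the group on the carbonyl carbon and nothing else.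

Compound 4 `COc1cc(/C=C/C(=O)OCC(C)C)ccc1OS(=O)(=O)c1ccc(Cl)cc1` is the next one to be measured in this assay. It differs from compound 3 by methyl in place of hydrogen on a saturated chain carbon bound to two saturated chain carbons. Among the compounds with values here, the one measured step changes a different part of the molecule, so it offers no direct guide here. For so small an addition to a saturated chain, no step beyond the scatter is expected, and compound 4 is therefore estimated at 130000 nM, with a range from 50000 nM to 300000 nM. The expected step is a 1.2-fold lower number from compound 3 to compound 4 (0.06 log units; within the scatter), essentially flat.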

Compound 4, half-maximal cytotoxic concentration: 103000 nM
Compound 4: the middle estimate sits 1.3-fold (0.10 log units) above what was measured; measured number inside the range.
By their numbers in this assay, from the lowest: compound 1; then compound 2; then compounds 4 and 3 (each within the scatter of the next).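

With the step of a 1.5-fold lower number from compound 3 to compound 4 (0.16 log units; within the scatter) in this assay, the ester chain itself is changed for the first time among the compounds shown, since the earlier single-site step replaced the whole group on the carbonyl carbon. Going from propoxy to isobutoxy adds a methyl on a saturated chain carbon bound to two saturated chain carbons, and the two compounds cannot be told apart in this test. No other measurement here helps to explain this result.

On these data alone, one added methyl says little about larger changes, so it remains open how a longer chain such as hexyl, or an amine on this chain, would read. Compound 2 and compound 3 also differ in more than one place, so the shown compounds cannot trace their gap to any single group.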